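Demethylating the ether on a urea-triazole helicase inhibitor

A few compounds are considered here, and "the series" means these few. Any claim that something is new, unique, unknown or untested is made for them only; others in the source may bear on it.

The series shares a diaryl urea joined to a triazole that carries a short chain, and it was examined in an assay on isolated protein for inhibition of ATP-dependent RNA helicase DDX3X (Homo sapiens), read by FRET, with stated times of 30 s and 40 min; on this read-out lower numbers stand for stronger inhibition and higher numbers for weaker inhibition. Compound 1 `CCCCc1cn(-c2ccc(NC(=O)Nc3cc(CCC(C)=O)ccc3C)cc2)nn1` gives 2490 nM in this assay. Compound 2 `COCCc1cn(-c2ccc(NC(=O)Nc3ccccc3C)cc2)nn1` gives 1000 nM in this assay, the lowest of the two numbers reported; compound 1 stands a step above it that is beyond the usual scatter. Compound 3 `O=C(O)CCc1cn(-c2ccc(NC(=O)Nc3ccccc3C(F)(F)F)cc2)nn1`, which carries a carboxylic acid on its chain and a trifluoromethyl group on the urea, has no numerical result in this assay: its entry reads "not determined" (no result reported).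

Compound 4 `Cc1ccccc1NC(=O)Nc1ccc(-n2cc(CCO)nn2)cc1` differs from compound 2 only in the chain on the triazole: hydrogen in place of methyl on an oxygen on a saturated carbon. Among the measured compounds shown here, no single-change step between measured compounds is available to calibrate such a change, and the two numbers that exist concern other parts of the molecule. A small step, no larger than the scatter and in either direction, is expected; compound 4 is estimated at 1300 nM, within 500 nM to 3500 nM, which corresponds to an expected 1.3-fold higher number from compound 2 to compound 4 (0.11 log units; within the scatter).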

Compound 4, half-maximal inhibitory concentration: 13000 nM
The estimate for compound 4 lay 10-fold (1.00 log units) below the measured number; measured number outside the range, above it.
By their numbers in this assay, from the lowest: compound 2; then compound 1; then compound 4.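

In this assay, exchanging 2-methoxyethyl for 2-hydroxyethyl brings a 13-fold higher number from compound 2 to compound 4 (1.11 log units; beyond the scatter), the first single-change step available in this series, and a large one. The end of this chain is therefore a sensitive place: the loss of one methyl from the oxygen, a single carbon with no change in net charge, moves the number well beyond the scatter, and the methyl ether is the better of the two ends compared. Nothing measured here accounts for the size of this step.

From the compounds shown here alone, it remains open whether an ethoxy group, a longer ether chain or an amine at the same place would hold the number of compound 2 or improve on it. Going by these compounds, it is also open whether the same step would appear with a trifluoromethyl group on the urea.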